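Shortening the cyclohexyl ether chain: working notes

The source may hold more compounds than are shown below. What is called first, only, known or untested is meant among the compounds shown, and "the series" means these compounds.

Values in a functional assay on MDA-MB-231 cells (Homo sapiens) for antiproliferative activity, read by sulforhodamine B assay (on this read-out higher numbers stand for weaker inhibition of growth and lower numbers for stronger inhibition of growth), follow
- Compound 1 `CC(C)CCCOc1cccc(O)c1C(=O)/C=C/c1ccc(O)cc1` gives 3480 nM
- Compound 2 `O=C(/C=C/c1ccc(O)cc1)c1c(O)cccc1OCCC1CCCCC1` gives > 30000 nM (a limit, not a number)

Compound 2 has only a limit in this assay, namely > 30000 nM, so its position is not fixed by a number. Compound 3 `O=C(/C=C/c1ccc(O)cc1)c1c(O)cccc1OCC1CCCCC1` has not been measured. The change from compound 2 is cyclohexyl in place of cyclohexylmethyl on a saturated chain carbon bound to an oxygen on an aromatic ring. Among the measured compounds shown here, one measured step bears on this, an at least 8.6-fold higher number from compound 1 to compound 2 (0.93 log units; beyond the scatter), and it ends in a limit, so its full size is unknown. For the measured compounds named here, with that step as the only guide, and with the cyclohexyl group kept, compound 3 is expected to stay weak in this assay, moving modestly towards lower numbers at most. The expected step is an at least 2.0-fold lower number from compound 2 to compound 3 (0.30 log units; that floor lies within the scatter), and a result at the limit remains possible. Compound 3 is estimated at 15000 nM, with an expected range of 4000 nM to 50000 nM.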

Compound 3, concentration for 50% growth inhibition: > 30000 nM
Compound 3: a limit, no number; the forecaster's own chance of this, stated with the estimate: 45%; middle value at least 2.0-fold (0.30 log units) from the limit.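

In this assay compound 3 gives > 30000 nM, which is a limit and not a number. With the cyclohexyl group kept, the shorter cyclohexylmethyl ether therefore does not yield a measurable value, and cyclohexyl in place of isopentyl at this position gives an at least 8.6-fold higher number from compound 1 to compound 3 (0.93 log units; beyond the scatter). The effect of the shortening itself cannot be read because both values are limits: the limit of > 30000 nM in this assay, at which 2 of the 3 values shown sit.

On these data alone, how far compound 2 and compound 3 lie past the limit stays open, so neither can be ranked against the other. Also open, as far as these compounds go, is whether a longer unbranched chain, or an amine or a carboxylic acid at the end of the chain, would give a measurable value at this position.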